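The source may report more compounds than this note shows. Statements on the series, on what has been measured and on what is new or still open speak of the compounds shown alone.

Measured in a functional assay on HT-29 cells (Homo sapiens) for cytotoxicity, read by MTT assay, with a stated time of 72 h; a lower number here means a stronger inhibitor, a higher number a weaker inhibitor:
compound 1 `O=C(CN1CCN(c2nnc(Cc3ccncc3)c3ccccc23)CC1)Nc1ccc(Br)cc1`: 1990 nM
compound 2 `O=C(CN1CCN(c2nnc(Cc3ccccc3)c3ccccc23)CC1)Nc1ccc(F)c(C(F)(F)F)c1`: 4590 nM
compound 3 `O=C(CN1CCN(c2nnc(Cc3ccncc3)c3ccccc23)CC1)Nc1ccc(F)c(C(F)(F)F)c1`: 1110 nM

Of these three, compound 2 carries the highest number, at 4590 nM. The account follows the change from compound 2 to compound 4 `O=C(CN1CCN(c2nnc(Cc3ccccc3)c3ccccc23)CC1)Nc1ccc(F)c(F)c1`, which is not yet measured. The difference is fluoro in place of trifluoromethyl on an aromatic carbon, ortho to a fluoro group, which turns 4-fluoro-3-(trifluoromethyl)phenyl into 3,4-difluorophenyl.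

Among the measured compounds shown here, no measured step makes this exact change. The closest is a 1.8-fold lower number from compound 1 to compound 3 (0.25 log units; within the scatter), a swap of the group on the amide-type nitrogen, and it stayed small. The larger 4.1-fold lower number from compound 2 to compound 3 (0.62 log units; beyond the scatter) is pyridin-4-yl in place of phenyl, a change elsewhere in the molecule, so it bears only indirectly. On this evidence, no clear direction and no shift beyond the scatter is expected in this assay. The expected step is a 1.1-fold lower number from compound 2 to compound 4 (0.06 log units; within the scatter). For compound 4 the estimate is 4000 nM, with an expected range from 1800 nM to 9000 nM.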

Compound 4, half-maximal inhibitory concentration: 9510 nM
Compound 4: middle estimate off by 2.4-fold (0.38 log units), on the low side; the measured number lies above the stated range.
By their numbers in this assay, from the lowest: compounds 3 and 1 (each within the scatter of the next); then compound 2; then compound 4.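

In this assay the exchange of trifluoromethyl for fluoro, ortho to a fluoro group, gives a 2.1-fold higher number from compound 2 to compound 4 (0.32 log units; beyond the scatter) and so moves the number upward, towards weaker inhibition, by a modest step beyond the scatter. Among the compounds shown here, this is the first sign that a change on this aromatic ring can shift the number beyond the scatter, since the earlier swap on the amide-type nitrogen, a 1.8-fold lower number from compound 1 to compound 3 (0.25 log units; within the scatter) with pyridin-4-yl in the other place, stayed within it. Nothing available explains why the smaller fluoro gives the higher number.

The compounds shown leave open whether 3,4-difluorophenyl would give a step of this direction and size alongside pyridin-4-yl. They also leave open how a chloro, methoxy or nitrile group would read on the same aromatic carbon.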